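Naphthyl Analogue of a Pyrazolyl Oxindole Series

A few compounds are considered here, and "the series" means these few. Any claim that something is new, unique, unknown or untested is made for them only; others in the source may bear on it.

Measured compounds in a functional assay on cells (Leukemia cell, Homo sapiens) for cytotoxicity, read by sulforhodamine B assay, with a stated time of 48 h; a lower number here means a stronger inhibitor of growth, a higher number a weaker inhibitor of growth:
Compound 1 `O=C1N=C(N2N=C(c3ccccc3)CC2c2ccccc2O)S/C1=C1/C(=O)Nc2ccccc21`: 3190 nM
Compound 2 `COc1ccc(-c2cc(-c3ccc(Cl)cc3)n(C3C(=O)Nc4ccc(Br)cc43)n2)cc1`: 12400 nM
Compound 3 `COc1ccc(-c2cc(-c3ccc(Cl)cc3)n(C3C(=O)Nc4ccc(Cl)cc43)n2)cc1`: 28000 nM

Compound 2 stands second highest of the three numbers in this assay. Among the measured compounds shown here, its nearest neighbour is compound 3, and the one measured step, a 2.3-fold higher number from compound 2 to compound 3 (0.35 log units; beyond the scatter), is a modest change that comes with the halogen swap alone. Compound 1, built on a different core, gives 3190 nM and lies furthest from compound 2.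

The unmeasured compound 4 `O=C1Nc2ccc(Br)cc2C1n1nc(-c2ccc3ccccc3c2)cc1-c1ccc(Cl)cc1` arises from compound 2 by naphthalen-2-yl in place of 4-methoxyphenyl on an aromatic carbon. For the measured compounds named here, no measured step touches this position: the only step on record, from compound 2 to compound 3, concerns the halogen on the fused ring and says nothing about the group on the five-membered aromatic ring with two nitrogen atoms. The shared core of compounds 2, 3 and 4 is kept, and the bromo substituent of compound 2 is retained in compound 4.

Going by the values given here, with no direct precedent, the expectation is that compound 4 stays near compound 2, that is a step of a 1.1-fold lower number from compound 2 to compound 4 (0.05 log units; within the scatter), not clearly beyond the scatter in either direction. Compound 4 is therefore estimated at 11000 nM, with a range from 3500 nM to 35000 nM.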

Compound 4, concentration for 50% growth inhibition: 10400 nM
Compound 4: the middle estimate sits 1.1-fold (0.02 log units) above what was measured; the measured number falls inside the stated range.
By their numbers in this assay, from the lowest: compound 1; then compounds 4 and 2 (each within the scatter of the next); then compound 3.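

In this assay, among the compounds shown here, the position on the aromatic carbon of the five-membered aromatic ring with 2 nitrogen, two ring bonds from the ring atom that bears a 4-chlorophenyl group, now has a measured step of its own, a 1.2-fold lower number from compound 2 to compound 4 (0.08 log units; within the scatter), and this is the first reading of any change at this place. Naphthalen-2-yl in place of 4-methoxyphenyl adds a second six-membered aromatic ring of carbon and gives up the hydrogen-bond acceptor of the leaving group, yet the read-out does not separate compound 2 from compound 4. For the compounds shown here, the halogen swap, a 2.3-fold higher number from compound 2 to compound 3 (0.35 log units; beyond the scatter), therefore remains the only step in this shared core that lies beyond the scatter, and nothing at hand offers an explanation for either result.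

The compounds shown leave open whether a group on this carbon bearing an amine or a carboxylic acid, or a small group such as methyl, would shift the number beyond the scatter. They also leave open whether naphthalen-2-yl would give a similar reading alongside the chloro substituent of compound 3.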